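From Isobutoxy to Cyclopropylmethoxy on a Shared Core

The source may hold more compounds than are shown below. What is called first, only, known or untested is meant among the compounds shown, and "the series" means these compounds.

In a functional assay on the whole organism (strain Sprague-Dawley) for inhibition, with Rattus norvegicus as the target, with a stated time of 10 min (a lower number here means that less compound is needed, a higher number that more compound is needed for the effect), compound 1 `CCCOc1ccccc1-c1ncc(C(=O)O)c(=O)[nH]1` gives 0.9 mg/kg and compound 2 `CC(C)COc1ccccc1-c1ncc(C(=O)O)c(=O)[nH]1` gives 0.5 mg/kg, so the two values lie within the scatter of each other. The next structure, compound 3 `O=C(O)c1cnc(-c2ccccc2OCC2CC2)[nH]c1=O`, has cyclopropyl in place of isopropyl on a saturated chain carbon bound to an oxygen on an aromatic ring, which turns isobutoxy into cyclopropylmethoxy: cyclopropyl in place of isopropyl on a saturated chain carbon bound to an oxygen on an aromatic ring. Going by the values given here, only one measured step bears on this change, a 1.8-fold lower number from compound 1 to compound 2 (0.26 log units; within the scatter), and it also alters the same chain, with methyl in place of hydrogen. That step stays small, so no step beyond the scatter is expected in this assay. The step expected is no change at the digits printed from compound 2 to compound 3 (within the scatter). For compound 3 the estimated value is 0.5 mg/kg, with an expected range from 0.2 mg/kg to 1.2 mg/kg.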

Compound 3, dose for 50% inhibition: 0.1 mg/kg
For compound 3 the middle estimate is 5.0-fold (0.70 log units) above the measured one, outside the stated range (below it).
By their numbers in this assay, from the lowest: compound 3; then compounds 2 and 1 (each within the scatter of the next).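

In this assay, going by these compounds alone, cyclopropyl in place of isopropyl on a saturated chain carbon bound to an oxygen on an aromatic ring gives a 5.0-fold lower number from compound 2 to compound 3 (0.70 log units; beyond the scatter) and is the first change at this position to pass beyond the scatter. Measured against the propoxy chain, the change gives a 9.0-fold lower number from compound 1 to compound 3 (0.95 log units; beyond the scatter) while the methyl step among the open chains, a 1.8-fold lower number from compound 1 to compound 2 (0.26 log units; within the scatter), stayed small, and isopropyl and cyclopropyl both count 3 heavy atoms, so the two groups differ here in the three-membered ring. Nothing shown accounts for this step.

The compounds shown leave open whether cyclobutyl or cyclopentyl on the same carbon would keep the lower number. They also leave open whether an added methyl or fluorine on the cyclopropyl ring would keep it.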